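This account rests on a few compounds, and the source may have more. Where it says the series, first, only, none or still open, it means among the compounds named here.

Measured so far:
compound 1, `CN1CCN(c2ccc(C3=NN(S(=O)(=O)c4ccc(C(F)(F)F)cc4)C(c4ccc(N(C)C)cc4)C3)cc2)CC1` — 18.9%
compound 2, `CC(=O)N1N=C(c2ccc(-n3cncn3)cc2)CC1c1ccc(N(C)C)cc1` — -0.3%

Both were read in a functional assay on NCI-H1975 cells (Homo sapiens) for inhibition, read by sulforhodamine B assay, tested at 10 uM; a higher number here means more inhibition at the concentration tested (going by the name of the read-out), a lower number less inhibition. Compound 2 stands lowest of the two numbers, with compound 1 the nearest and higher by a gap beyond the usual scatter. Compound 3, `CN(C)c1ccc(C2CC(c3ccc(-n4cncn4)cc3)=NN2S(C)(=O)=O)cc1`, is not yet measured. It differs from compound 2 in one place: methylsulfonyl in place of acetyl on an amine nitrogen in a ring. Among the compounds with values here, no step between measured compounds covers this change. Because compound 2 sits at -0.3%, the step of a number 5.3 percentage points higher from compound 2 to compound 3 (within the scatter) is expected to be a small rise at most, likely within the scatter. Compound 3 is expected to give 5%, in the range -10% to 22%.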

Compound 3, a percentage reported as inhibition, at one concentration (the size of the read-out at that concentration, not a potency): -3.1%
The estimate for compound 3 lay 8.1 percentage points above the measured number; the measured number falls inside the stated range.
By their numbers in this assay, from the lowest: compounds 3 and 2 (each within the scatter of the next); then compound 1.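

Methylsulfonyl in place of acetyl on an amine nitrogen in a ring gives a number 2.8 percentage points lower from compound 2 to compound 3 (within the scatter) in this assay, so this change does not separate compound 2 and compound 3 at the concentration tested. At this position, the acetyl carbonyl is therefore not required for the reading to stay where it is, and a sulfonyl group serves equally. No supporting measurement bears on this result.

Compound 1 differs from both in more than one place, so its number cannot be assigned to either change. Still open, going by these compounds, is whether a larger group on this nitrogen, such as benzoyl or a longer acyl chain, would move the reading.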